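Bromine removal in two isatin-type series

This account rests on a few compounds, and the source may have more. Where it says the series, first, only, none or still open, it means among the compounds named here.

Measured so far:
Compound 1, `Cc1ccc2nc(/N=C3\C(=O)N(CN(c4ccccc4)c4ccccc4)c4cccc(Br)c43)sc2c1`, in a functional assay on MDA-MB-468 cells (Homo sapiens) for cytotoxicity, read by sulforhodamine B assay, with a stated time of 48 h (on this read-out higher numbers stand for weaker inhibition of growth and lower numbers for stronger inhibition of growth), compound 1 gives 82300 nM.
Compound 2, `CN(C)CN1C(=O)C(=O)c2c(Br)cccc21`, in this assay compound 2 gives 49000 nM.
Compound 3, `Cc1ccc2nc(/N=C3\C(=O)N(CN(c4ccccc4)c4ccccc4)c4ccccc43)sc2c1`, in this assay compound 3 gives 17700 nM.

Compound 1 and compound 3 differ by one change, (hydrogen in place of bromo on an aromatic carbon), and that change gave a 4.6-fold lower number from compound 1 to compound 3 (0.67 log units; beyond the scatter). Compound 2 carries a different core; how the two cores differ is not broken down here. Compound 4, `CN(C)CN1C(=O)C(=O)c2ccccc21`, is not yet measured. Within the data shown here, it relates to compound 2 through (hydrogen in place of bromo on an aromatic carbon), which is the same change as the one from compound 1 to compound 3, at the same place on the ring.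

Among the measured compounds shown here, the step from compound 2 to compound 4 is expected to be a 3.1-fold lower number from compound 2 to compound 4 (0.49 log units; beyond the scatter) in this assay, resting on the step seen from compound 1 to compound 3, a 4.6-fold lower number from compound 1 to compound 3 (0.67 log units; beyond the scatter), though with caution: the core of compound 2 is smaller, and only one such step is known. Compound 4 is therefore estimated at 16000 nM, likely between 6000 nM and 45000 nM.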

Compound 4, concentration for 50% growth inhibition: 50200 nM
Compound 4: the middle estimate sits 3.1-fold (0.50 log units) below what was measured; measured number above the stated range.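

On the smaller core, hydrogen in place of bromo gave a 1.0-fold higher number from compound 2 to compound 4 (0.01 log units; within the scatter), so the change that mattered on the larger core made no measurable difference here. In this assay, the same change therefore did not carry over from one core to the other: the same change on two cores in this assay, a 4.6-fold lower number (0.67 log units; beyond the scatter) from compound 1 to compound 3 and a 1.0-fold higher number (0.01 log units; within the scatter) from compound 2 to compound 4, 4.8-fold (0.68 log units) apart, beyond the scatter of two such steps. Among these compounds, this shows that the size of the step cannot simply be transferred between these two cores, but with only two pairs it does not show which part of the cores accounts for the gap, or what the change would do on a third core.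

As far as these compounds go, it remains open how a chloro or methoxy group on the same aromatic carbon would compare with bromo and hydrogen on each core.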